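The source may report more compounds than this note shows. Statements on the series, on what has been measured and on what is new or still open speak of the compounds shown alone.

Measured so far in a functional assay on CCRF-CEM cells (Homo sapiens) for inhibition, read by sulforhodamine B assay, with a stated time of 48 h, tested at 10 uM; a lower number here means a stronger effect, a higher number a weaker effect of the compound at the concentration tested:
Compound 1, `COc1cc(Cl)cc(-c2nn(-c3cccc(NC(=O)c4ccc(Cl)c(Cl)c4)c3)cc2-c2ccncc2)c1`: compound 1 gives 59.2%.
Compound 2, `O=C(Nc1cccc(-n2cc(-c3ccncc3)c(-c3cc(O)cc(Cl)c3)n2)c1)Nc1ccc(Cl)c(Cl)c1`: compound 2 gives 4.11%.
Compound 3, `COc1cc(Cl)cc(-c2nn(-c3cccc(NC(=O)Nc4ccc(Cl)c(Cl)c4)c3)cc2-c2ccncc2)c1`: compound 3 gives 5.73%.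

Among these three numbers compound 3 stands second highest; its nearest neighbour, compound 2, lies within the usual scatter of it, while compound 1 lies far beyond. The step of a number 1.6 percentage points higher from compound 2 to compound 3 (within the scatter) shows that the methyl on the oxygen makes no trustworthy difference. The step of a number 53.5 percentage points lower from compound 1 to compound 3 (beyond the scatter) is the large one: turning the amide into a urea lowers the number sharply, which means a much stronger effect.

Compound 4, `COc1cc(Cl)cc(-c2nn(-c3cccc(NC(=O)c4cccc(C(F)(F)F)c4)c3)cc2-c2ccncc2)c1`, is not yet measured. It differs from compound 3 in one place: 3-(trifluoromethyl)phenyl in place of (3,4-dichlorophenyl)amino on a carbonyl carbon. This undoes the urea and puts an aryl directly on the carbonyl, as in compound 1, so the large step above bears on it in reverse. Among the compounds with values here, the entering 3-(trifluoromethyl)phenyl is not the 3,4-dichlorophenyl of compound 1, and no measured pair tells how that matters, so the guess is rough. Compound 4 is expected to show a number 49.3 percentage points higher from compound 3 to compound 4 (beyond the scatter), a large rise in the number. The estimate for compound 4 is 55%, within a range from 28% to 85%.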

Compound 4, a percentage reported as activity, at one concentration (the size of the read-out at that concentration, not a potency): 42.3%
Compound 4: middle estimate off by 12.7 percentage points, on the high side; low and high end bracket the measured number.
By their numbers in this assay, from the lowest: compounds 2 and 3 (each within the scatter of the next); then compound 4; then compound 1.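

In this assay, replacing the (3,4-dichlorophenyl)amino on the carbonyl carbon with 3-(trifluoromethyl)phenyl gives a number 36.6 percentage points higher from compound 3 to compound 4 (beyond the scatter), so a second amide also stands well above the urea. The new point is that the aryl group on the amide carbonyl matters too: exchanging 3,4-dichlorophenyl for 3-(trifluoromethyl)phenyl gives a number 16.9 percentage points lower from compound 1 to compound 4 (beyond the scatter), a modest gain that does not bring the number back near that of the urea. Nothing measured here explains either step.

As far as these compounds go, because the step from the urea to compound 4 alters both the linking nitrogen and the ring substituents, the share of each remains open, including what a urea carrying 3-(trifluoromethyl)phenyl would give. Also open, from the compounds shown here alone, is how this position would respond to an aryl ring bearing an amine or a carboxylic acid, or to a longer chain in place of the aryl ring.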